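Three benzylamines on a shared core, and a nitrile next

The source may report more compounds than this note shows. Statements on the series, on what has been measured and on what is new or still open speak of the compounds shown alone.

Compound 1, `Cc1ccc(CNc2nc(-c3ccccc3C(F)(F)F)nc3ccccc23)s1`, gives 5100 nM in an assay on a protein complex for inhibition of ubiquitin carboxyl-terminal hydrolase 1/WD repeat-containing protein 48 (Homo sapiens), read by fluorescence; a lower number here means a stronger inhibitor, a higher number a weaker inhibitor.
Compound 2, `FC(F)(F)c1ccc(CNc2nc(-c3ccccc3C(F)(F)F)nc3ccccc23)cc1`, gives 8900 nM in this assay.
Compound 3, `FC(F)(F)c1ccccc1-c1nc(NCc2ccc(Cl)c(Cl)c2)c2ccccc2n1`, gives 10400 nM in this assay.

Compound 3 gives the highest of the three numbers in this assay. Its nearest neighbour is compound 2 through a 1.2-fold higher number from compound 2 to compound 3 (0.07 log units; within the scatter), and the step from compound 1 is a 2.0-fold higher number from compound 1 to compound 3 (0.31 log units; beyond the scatter). Compound 4, `N#Cc1ccc(CNc2nc(-c3ccccc3C(F)(F)F)nc3ccccc23)cc1`, has not yet been measured. It differs from compound 3 in one place: 4-cyanophenyl in place of 3,4-dichlorophenyl on a saturated chain carbon bound to a nitrogen on an aromatic ring.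

Going by the values given here, no measured step exchanges a 3,4-dichlorophenyl or a 4-cyanophenyl for one another, so the nearest guidance comes from the other exchanges at the same place. There, a 1.7-fold higher number from compound 1 to compound 2 (0.24 log units; within the scatter) and a 1.2-fold higher number from compound 2 to compound 3 (0.07 log units; within the scatter) were both small, while a 2.0-fold higher number from compound 1 to compound 3 (0.31 log units; beyond the scatter) was modest. Three different groups at this position have thus moved the number only a little. Compound 4 is therefore expected to land near compound 3, with the step of a 1.2-fold lower number from compound 3 to compound 4 (0.06 log units; within the scatter) anticipated to stay within the usual scatter, in no particular direction. For compound 4 the estimate in this assay is 9000 nM, with a range of 3500 nM to 25000 nM.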

Compound 4, half-maximal inhibitory concentration: 5700 nM
For compound 4 the middle estimate is 1.6-fold (0.20 log units) above the measured one; low and high end bracket the measured number.
By their numbers in this assay, from the lowest: compounds 1, 4, 2 and 3 (each within the scatter of the next, the first and the last beyond it).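

In this assay, 4-cyanophenyl brings a triple bond and a hydrogen-bond acceptor that 3,4-dichlorophenyl lacks, yet the exchange stays within the scatter (a 1.8-fold lower number from compound 3 to compound 4 (0.26 log units; within the scatter)). The same holds for cyano in place of trifluoromethyl on an aromatic carbon (a 1.6-fold lower number from compound 2 to compound 4 (0.19 log units; within the scatter)) and for 4-cyanophenyl in place of 5-methylthiophen-2-yl (a 1.1-fold higher number from compound 1 to compound 4 (0.05 log units; within the scatter)), so compound 4 cannot be separated from any of the three earlier compounds. Nothing available explains why these groups read so much alike.

On these data alone, all four groups at this place are aromatic rings, so it remains open what a saturated cyclohexyl ring, or an amine or a carboxylic acid on the phenyl ring, would do. As far as these compounds go, the rest of the shared core is the same in all four compounds, so the effect of any change there also remains open.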